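Ester to acid on a glucoside indole series

A few compounds are considered here, and "the series" means these few. Any claim that something is new, unique, unknown or untested is made for them only; others in the source may bear on it.

Measured so far:
compound 1 `COc1ccc2c(ccn2-c2ccc(O[C@H]3O[C@H](CO)[C@@H](O)[C@H](O)[C@@H]3O)c(Cl)c2)c1`: 96%
compound 2 `COC(=O)c1ccc2c(ccn2-c2ccc(O[C@H]3O[C@H](CO)[C@@H](O)[C@H](O)[C@@H]3O)c(Cl)c2)c1`: 99%

Both compounds were tested in an ADME assay on a cell-free system (plasma, Homo sapiens) for protein binding, read by LC-MS, with a stated time of 5 h, tested at 10 uM. Among the two measured compounds, compound 2 shows the lowest unbound fraction; the only step recorded, a 4.0-fold lower unbound fraction from compound 1 to compound 2 (0.60 log units; beyond the scatter), lies beyond the scatter.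

Compound 3 `O=C(O)c1ccc2c(ccn2-c2ccc(O[C@H]3O[C@H](CO)[C@@H](O)[C@H](O)[C@@H]3O)c(Cl)c2)c1` has not yet been measured. Its change from compound 2 is hydrogen in place of methyl on an oxygen next to a carbonyl group, which in longer form reads methoxycarbonyl to carboxy.

Among the measured compounds shown here, no measured step covers this change: the one step known exchanges methoxy for methoxycarbonyl, a different group, so it gives only indirect guidance. The estimate therefore rests mainly on compound 2 staying close to its own value. A small step toward a higher unbound fraction is expected, a 3.0-fold higher unbound fraction from compound 2 to compound 3 (0.48 log units; beyond the scatter), with wide uncertainty. Compound 3 is estimated at 97%, with a range from 90% to 99.5%.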

Compound 3, plasma protein binding in the plasma assay: 93%
Estimate against measurement, compound 3: 2.3-fold (0.37 log units) (unbound fraction) below; low and high end bracket the measured number.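

Going from methoxycarbonyl to carboxy gives the first direct reading of this change in the plasma assay, with a 7.0-fold higher unbound fraction from compound 2 to compound 3 (0.85 log units; beyond the scatter) as the result, so losing one methyl from this oxygen frees a clear share of the compound. Carboxy and methoxy on this aromatic carbon cannot be told apart on this read-out, with a 1.8-fold higher unbound fraction from compound 1 to compound 3 (0.24 log units; within the scatter) as their step, so the extra binding appears with methoxycarbonyl alone among the three groups. The higher unbound fraction may follow from a drop in lipophilicity, because the same change also moves the result in a physicochemical assay for lipophilicity, using the shake flask method, in phosphate buffer, measured as octanol-water partition, with a stated time of 2 h, at pH 7.4, tested at 1 uM; on this read-out lower numbers stand for lower lipophilicity and higher numbers for higher lipophilicity: the measured distribution coefficient of compound 2, 2.8, and of compound 3, 1.1, a number 1.70 log units lower (beyond the scatter). In the physicochemical assay compound 2 gives 2.8 and compound 3 gives 1.1.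

The compounds shown leave open how an amide or an amine in this place would behave in the plasma assay. As far as these compounds go, whether binding tracks lipophilicity beyond this single pair also remains open.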